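Glucagon receptor series: pyrazolyl ether amides, working notes

The source may hold more compounds than are shown below. What is called first, only, known or untested is meant among the compounds shown, and "the series" means these compounds.

Measured so far:
compound 1, `O=C(O)CCNC(=O)c1ccc(C(Oc2ccc(-n3cc(C(F)(F)F)cn3)cc2)C2CCC2)cc1`, 700 nM
compound 2, `CCCC(Oc1ccc(-n2cc(C(F)(F)F)c(C)n2)cc1)c1ccc(C(=O)NCCC(=O)O)cc1`, 1100 nM

Compound 2 gives the highest number of the two in an assay on cells for displacement of a labelled ligand from Glucagon receptor (Homo sapiens), in the presence of a further agent that is not named here (on this read-out lower numbers stand for stronger inhibition and higher numbers for weaker inhibition), with compound 1 the nearer neighbour; the gap between them lies within the scatter, so the two read as equal on this assay.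

Compound 3, `CCCC(Oc1ccc(-n2cc(Cl)cn2)cc1)c1ccc(C(=O)NCCC(=O)O)cc1`, differs from compound 2 in one place: 4-chloro-1H-pyrazol-1-yl in place of 3-methyl-4-(trifluoromethyl)-1H-pyrazol-1-yl on an aromatic carbon. Among the measured compounds shown here, no step between measured compounds covers this change, so the expectation rests on the position of compound 2 alone. With fewer heavy atoms in the entering group, a small loss of inhibition in this assay is expected, of a size that may not clear the scatter.

Compound 3 is expected to give 2000 nM in this assay, with a likely range from 800 nM to 5000 nM. This estimate means a step of a 1.8-fold higher number from compound 2 to compound 3 (0.26 log units; within the scatter).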

Compound 3, inhibition constant: 1100 nM
Estimate against measurement, compound 3: 1.8-fold (0.26 log units) above; low and high end bracket the measured number.
By their numbers in this assay, from the lowest: compounds 1, 2 and 3 (each within the scatter of the next).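

In this assay, 4-chloro-1H-pyrazol-1-yl in place of 3-methyl-4-(trifluoromethyl)-1H-pyrazol-1-yl, on an aromatic carbon para to a large group, gives no change at the digits printed from compound 2 to compound 3 (within the scatter), the first read-out of a single change in the series. At this place, the entering group can carry fewer heavy atoms than the leaving group, with chlorine as the only substituent on the pyrazole, and the number stays the same. No measurement here explains why the number holds.

Among the compounds shown here, the single change removes methyl and swaps trifluoromethyl for chlorine together, so the share of each stays unresolved. Also open, going by these compounds, is whether a nitrile or a methoxy group on the pyrazole, or an unsubstituted 1H-pyrazol-1-yl, would keep the number in this range.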